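The source may report more compounds than this note shows. Statements on the series, on what has been measured and on what is new or still open speak of the compounds shown alone.

Compound 1 `CS(=O)(=O)Nc1ccc(Cl)c2c1CCCC2c1c[nH]cn1` was studied in an assay on isolated protein (Cricetulus griseus) for binding affinity to Alpha-1B adrenergic receptor (Mesocricetus auratus), read by radioligand binding; on this read-out higher numbers stand for weaker inhibition and lower numbers for stronger inhibition. In this assay compound 1 gives < 10000 nM, which is a limit of the assay rather than a measured number. A second compound, compound 2 `CCS(=O)(=O)Nc1cccc2c1CCCC2CNC`, was also studied. In this assay compound 2 gives < 10000 nM, again only a limit. Within the data shown here, both readings sit at the limit of < 10000 nM in this assay, at which 2 of the 2 values shown sit, so no step between measured compounds can be sized, and the place of compound 1 among the numbers is known only as this limit. Compound 3 `CS(=O)(=O)Nc1ccc(F)c2c1CCCC2c1c[nH]cn1` differs from compound 1 by fluoro in place of chloro on an aromatic carbon. This change is expected to make little difference, a step that the limit leaves unreadable from compound 1 to compound 3, a step within the usual scatter in either direction. Compound 3 is therefore estimated to give about 1500 nM in this assay, expected to fall between 200 nM and 8000 nM.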

Compound 3, inhibition constant: < 10000 nM
Compound 3 was reported as a limit (the forecaster's own chance of this, stated with the estimate: 40%); the middle value is on the limit's open side.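

Compound 1 and compound 3 are each known only as a limit, so no step between them can be read: the limit of < 10000 nM in this assay, at which 3 of the 3 values shown sit.

As far as these compounds go, how fluoro and chloro compare on that aromatic carbon in this assay stays open, as does the actual strength of each compound.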